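Two Limits and an Untested Urea Analogue

The compounds below may be only part of what the source reports. "The series", "measured", "known", "first", "only" and "open" are said of these compounds alone.

Compound 1, `COc1cc(-c2nn(-c3cccc(NC(=O)Nc4ccc(Cl)c(Cl)c4)c3)cc2-c2ccncc2)ccc1Cl`: in a functional assay on SF-295 cells (Homo sapiens) for inhibition, read by sulforhodamine B assay, with a stated time of 48 h (a lower number here means that less compound is tolerated, a higher number that more compound is tolerated), compound 1 gives only the assay limit > 50000 nM.
Compound 2, `COc1cc(-c2nn(-c3cccc(NC(=O)c4ccc(Cl)c(C(F)(F)F)c4)c3)cc2-c2ccncc2)ccc1Cl`: in this assay compound 2 gives only the assay limit > 32500 nM.

Compound 2 therefore stands at a limit, not at a number. Among the measured compounds shown here, the one further value shown is a limit as well, as the limit of > 50000 nM in this assay, at which 1 of the 2 values shown sits, and the limit of > 32500 nM in this assay, at which 1 of the 2 values shown sits, make plain, so the step that the two limits leave unreadable from compound 1 to compound 2 cannot be sized.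

Compound 3, `COc1cc(-c2nn(-c3cccc(NC(=O)Nc4ccc(Cl)c(C(F)(F)F)c4)c3)cc2-c2ccncc2)ccc1Cl`, differs from compound 2 by (4-chloro-3-(trifluoromethyl)phenyl)amino in place of 4-chloro-3-(trifluoromethyl)phenyl on a carbonyl carbon. For the measured compounds named here, the only measured step touches this kind of change, but it alters two things at once and its size is not readable, so no measured step gives a usable size here. With both neighbours sitting at limits, the expectation for the step that the limit leaves unreadable from compound 2 to compound 3 is that nothing beyond the scatter will be readable. Compound 3 is estimated to give 50000 nM, within 20000 nM to 100000 nM, most probably reported again as a limit.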

Compound 3, concentration lethal to 50% of the cells: 14900 nM
The estimate for compound 3 lay 3.4-fold (0.53 log units) above the measured number; measured number below the stated range.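

Among the compounds shown here, compound 3 is the first compound here to give a number rather than a limit in this assay, and both single changes that lead to it lower the tolerated concentration: the amino link on the carbonyl carbon gives an at least 2.1-fold lower number from compound 2 to compound 3 (0.33 log units; beyond the scatter), and trifluoromethyl in place of chloro on an aromatic carbon gives an at least 3.3-fold lower number from compound 1 to compound 3 (0.52 log units; beyond the scatter). The first size is only a minimum because compound 2 stands at a limit of the assay: the limit of > 32500 nM in this assay, at which 1 of the 3 values shown sits. The second size is only a minimum because compound 1 also stands at a limit of the assay: the limit of > 50000 nM in this assay, at which 1 of the 3 values shown sits.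

On these data alone, the step between compound 1 and compound 2 still cannot be read, so the true sizes of all these changes remain unknown. Also open, as far as these compounds go, is how the number would move with a nitrile or a methyl group in place of the trifluoromethyl of compound 3.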